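The compounds below may be only part of what the source reports. "The series", "measured", "known", "first", "only" and "open" are said of these compounds alone.

Measured compounds:
- compound 1 `Cc1cccc(NC(=O)CCN2CCN(c3ccccn3)CC2)c1` — 30%
- compound 2 `Cc1cccc(NC(=O)CN2CCN(c3ccc(Cl)cn3)CC2)c1` — "not active" (no number reported)

Compound 1 is a partial agonist in a functional assay on cells for agonist activity at D(4) dopamine receptor (Homo sapiens), read by TR-FRET and cAMP accumulation, with a stated time of 30 min; a higher number here means a larger maximal response, a lower number a smaller maximal response: in this assay compound 1 reaches 30%, a modest maximal response. For the measured compounds named here, it is the only compound of this small set with a number. Going by the values given here, compound 2 differs from compound 1 in more than one place, and in this assay compound 2 is reported only as "not active" (no number reported), so the two entries give no single step that could be measured against the scatter.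

Compound 3 `Cc1cccc(NC(=O)CCN2CCN(c3ncccn3)CC2)c1` is not yet measured. It differs from compound 1 by a single exchange on the shared core: pyrimidin-2-yl in place of pyridin-2-yl on an amine nitrogen in a ring. The aromatic ring attached to the amine nitrogen in the ring is replaced by a closely related six-membered aromatic ring with one more nitrogen and one more hydrogen-bond acceptor.

Among the compounds with values here, with no measured step of comparable kind to lean on, the expected change from compound 1 to compound 3 is small, a number 5 percentage points lower from compound 1 to compound 3 (within the scatter), and may well fall within the scatter; a modest loss seems somewhat more likely than a gain given that compound 1 itself reaches only 30%. Compound 3 is therefore expected to reach about 25% in this assay, estimated between 5% and 45%.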

Compound 3, largest response reached (Emax), in percent of the reference or control that the assay uses: 13.7%
Estimate against measurement, compound 3: 11.3 percentage points above; measured number inside the range.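

In this assay, putting pyrimidin-2-yl in place of pyridin-2-yl on the amine nitrogen in the ring gives a number 16.3 percentage points lower from compound 1 to compound 3 (beyond the scatter). For the compounds shown here, this is the first single change in the set that can be read, and it shows that the maximal response is sensitive at this position, even to a small exchange: both groups are six-membered aromatic rings with 6 heavy atoms and no net charge, and only the hetero atom count and hydrogen-bond acceptor count go from 1 to 2. Nothing available here explains why the response falls with this exchange.

Compound 2 differs from compound 1 in more than one place and has no number, so it cannot separate the effect of this exchange from that of any other change. As far as these compounds go, it remains open whether a plain phenyl ring or a pyrazin-2-yl group on the same nitrogen would keep, lower or raise the response, and so whether the drop belongs to pyrimidin-2-yl in particular or to ring nitrogens more generally.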